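Removing a Ring Nitrogen Methyl from Compound 1

A few compounds are considered here, and "the series" means these few. Any claim that something is new, unique, unknown or untested is made for them only; others in the source may bear on it.

Compound 1 `CC(C)C(CC1C(=O)NC(=O)N1C)c1ccc(-c2ccc3cccc(F)c3c2)[nH]c1=O`: 17 nM
Compound 2 `CCC(/C=C1\OC(=O)NC1=O)(CC)c1ccc(-c2ccc3cccc(F)c3c2)[nH]c1=O`: 13 nM
Compound 3 `CCC(CC)C(/C=C1\OC(=O)NC1=O)c1ccc(-c2ccc3cccc(F)c3c2)[nH]c1=O`: 13 nM

In an assay on membranes from Chem-1 cells for displacement of a labelled ligand from prostaglandin E2 receptor EP3 subtype (Homo sapiens), read by scintillation counting, with a stated time of 2 h (a lower number here means a stronger inhibitor, a higher number a weaker inhibitor), compound 1 gives 17 nM, the highest of the three numbers. Compound 2 gives 13 nM and compound 3 gives 13 nM, both within the scatter of the value for compound 1, so the three cannot be set in order. Compound 4 `CC(C)C(CC1NC(=O)NC1=O)c1ccc(-c2ccc3cccc(F)c3c2)[nH]c1=O` has not been measured; it differs from compound 1 in one place: hydrogen in place of methyl on an amide-type nitrogen in a ring. Among the measured compounds shown here, no measured pair shows what this change does, so nothing beyond the structures themselves guides the expectation. The expected step is a 1.1-fold lower number from compound 1 to compound 4 (0.05 log units; within the scatter), not beyond the scatter. Compound 4 is therefore estimated at 15 nM, with a range from 6 nM to 45 nM.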

Compound 4, inhibition constant: 10 nM
For compound 4 the middle estimate is 1.5-fold (0.18 log units) above the measured one; measured number inside the range.
By their numbers in this assay, from the lowest: compounds 4, 2, 3 and 1 (each within the scatter of the next).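

In this assay, putting hydrogen in place of methyl on the amide-type nitrogen in the ring gives a 1.7-fold lower number from compound 1 to compound 4 (0.23 log units; within the scatter). Among the compounds shown here, this is the first pair that differs only at this position, and it shows that the methyl is not needed to keep the number in this range. No measurement shown bears on the reason for this result.

As far as these compounds go, whether an ethyl group, a longer chain or a chain ending in a carboxylic acid would be tolerated on this nitrogen remains open.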